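This account rests on a few compounds, and the source may have more. Where it says the series, first, only, none or still open, it means among the compounds named here.

Three compounds sharing one core were tested in a functional assay on HL-60 cells (Homo sapiens) for cytotoxicity, read by CCK-8 assay, with a stated time of 24 h; a higher number here means a weaker inhibitor, a lower number a stronger inhibitor. Compound 1 `C=CC(=O)N1C(=O)CC(c2ccc([N+](=O)[O-])cc2)Sc2ccccc21` gives 107000 nM there. Compound 2 `C=CC(=O)N1C(=O)CC(c2ccc(OC)cc2)Sc2ccccc21` gives 92100 nM in this assay. Compound 3 `C=CC(=O)N1C(=O)CC(c2ccc(Cl)cc2)Sc2ccccc21` gives 95700 nM in this assay. Compound 2 does not stand apart from the other two: the step of a 1.2-fold lower number from compound 1 to compound 2 (0.07 log units; within the scatter) and the step of a 1.0-fold higher number from compound 2 to compound 3 (0.02 log units; within the scatter) both lie within the scatter, as does a 1.1-fold lower number from compound 1 to compound 3 (0.05 log units; within the scatter). Compound 4 `C=CC(=O)N1C(=O)CC(c2ccccc2)Sc2ccccc21` differs from compound 2 in one place: hydrogen in place of methoxy on an aromatic carbon. Going by the values given here, the steps that bear on this change are those in which the group on this same aromatic carbon was exchanged, and none of them moved the number beyond the scatter. A step of no real size is therefore expected, a 1.0-fold higher number from compound 2 to compound 4 (0.01 log units; within the scatter). Compound 4 is estimated to give 95000 nM, within a range from 50000 nM to 180000 nM.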

Compound 4, half-maximal inhibitory concentration: 97400 nM
The estimate for compound 4 lay 1.0-fold (0.01 log units) below the measured number, within the range that was stated.
By their numbers in this assay, from the lowest: compounds 2, 3, 4 and 1 (each within the scatter of the next).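

Compound 4 carries only hydrogen on this aromatic carbon, so it adds a comparison with no group there at all, and in this assay all three steps stay within the scatter: a 1.1-fold higher number from compound 2 to compound 4 (0.02 log units; within the scatter), a 1.0-fold higher number from compound 3 to compound 4 (0.01 log units; within the scatter) and a 1.1-fold lower number from compound 1 to compound 4 (0.04 log units; within the scatter). Among these four compounds, methoxy, chloro and nitro therefore read the same as hydrogen. Nothing measured here explains this lack of difference. On these data alone, whether an amine or a carboxylic acid on this same carbon would move the number beyond the scatter stays open.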